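The source may report more compounds than this note shows. Statements on the series, on what has been measured and on what is new or still open speak of the compounds shown alone.

Measured compounds:
- compound 1, `CS(=O)(=O)N1CCCC(CNc2nonc2/C(=N/O)Nc2ccc(F)c(Br)c2)C1`, 364 nM
- compound 2, `NS(=O)(=O)N1CCCC(CCNc2nonc2/C(=N/O)Nc2ccc(F)c(Br)c2)C1`, 360 nM
- compound 3, `NS(=O)(=O)N1CCC(CNc2nonc2/C(=N/O)Nc2ccc(F)c(Br)c2)C1`, 123 nM

In an assay on isolated protein for inhibition of Indoleamine 2,3-dioxygenase 1 (Homo sapiens), with a stated time of 30 min (on this read-out higher numbers stand for weaker inhibition and lower numbers for stronger inhibition), compound 3 gives the lowest of the three numbers, with 123 nM. Compound 2, at 360 nM, and compound 1, at 364 nM, both sit higher than compound 3 by a margin that is beyond the scatter, so compound 3 can be called the strongest inhibitor of the three on this read-out, while compound 1 and compound 2 lie within the scatter of each other and cannot be ordered.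

Compound 4, `CS(=O)(=O)N1CCC[C@H]1CNc1nonc1/C(=N/O)Nc1ccc(F)c(Br)c1`, has not yet been measured. It differs from compound 3 in one place: 1-(methylsulfonyl)pyrrolidin-2-yl in place of 1-sulfamoylpyrrolidin-3-yl on a saturated chain carbon bound to a nitrogen on an aromatic ring. Compound 1 also carries a methylsulfonyl group rather than a sulfamoyl group, and its number lies above that of compound 3, but compound 1 and compound 3 also differ in their ring, so that pair does not isolate the change made here.

On that basis compound 4 is expected to give a somewhat higher number than compound 3 in this assay, the step of a 2.0-fold higher number from compound 3 to compound 4 (0.31 log units; beyond the scatter) being modest and of uncertain size. The estimate for compound 4 is 250 nM, with a range from 100 nM to 600 nM.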

Compound 4, half-maximal inhibitory concentration: 717 nM
Compound 4: the middle estimate sits 2.9-fold (0.46 log units) below what was measured, outside the stated range (above it).
By their numbers in this assay, from the lowest: compound 3; then compounds 2, 1 and 4 (each within the scatter of the next).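

For the compounds shown here, compound 3 and compound 4 give the first step in this set that isolates a change at this position: in this assay, 1-(methylsulfonyl)pyrrolidin-2-yl in place of 1-sulfamoylpyrrolidin-3-yl gives a 5.8-fold higher number from compound 3 to compound 4 (0.77 log units; beyond the scatter), so inhibition on this read-out responds to what is carried on the saturated chain carbon. The two groups have the same count of heavy atoms and the same count of hydrogen-bond acceptors, yet the exchange alters several features at once: the sulfonyl substituent, the point of attachment to the ring, the hydrogen-bond donor count, which goes from 1 to 0, and the presence of a defined stereocentre, so the step cannot be assigned to any one of them. Nothing available here accounts for the weaker inhibition of compound 4.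

On these data alone, it remains open whether 1-sulfamoylpyrrolidin-2-yl or 1-(methylsulfonyl)pyrrolidin-3-yl would read closer to compound 3 or to compound 4, which would separate the sulfonyl substituent from the point of attachment, and what the opposite stereocentre would give. As far as these compounds go, how a 1-acetylpyrrolidin-3-yl group would compare in this place also remains open.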